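The compounds below may be only part of what the source reports. "The series", "measured", "known", "first", "only" and "open" are said of these compounds alone.

Within the data shown here, in a functional assay on the whole organism (Hindlimb, strain albino) with Mus musculus as the target, in the maximal electroshock model, with a stated time of 0.5 h (a lower number here means that less compound is needed, a higher number that more compound is needed for the effect), compound 3 `CC(=O)N1N=C(Nc2nc3ccccc3s2)CC1OC1=CC=C1` gives 382 umol/kg, the highest of the three numbers so far and beyond the scatter of the other two. Compound 1 `COc1ccc(C2CC(Nc3nc4ccc([N+](=O)[O-])cc4s3)=NN2C(C)=O)cc1O` gives 178 umol/kg, and compound 2 `CC(=O)N1N=C(Nc2nc3ccc([N+](=O)[O-])cc3s2)CC1c1ccc(O)cc1` gives 162 umol/kg. Compound 4 `CC(=O)N1N=C(Nc2nc3ccc([N+](=O)[O-])cc3s2)CC1OC1=CC=C1` differs from compound 3 by nitro in place of hydrogen on an aromatic carbon, which is nitro in place of hydrogen on an aromatic carbon. Among the measured compounds shown here, no measured step isolates this change. For the measured compounds named here, compounds 1 and 2 carry nitro but also differ from compound 3 elsewhere, and the one measured step, a 1.1-fold lower number from compound 1 to compound 2 (0.04 log units; within the scatter), does not involve nitro. A moderate move toward their values in this assay is therefore expected, though only tentatively. The estimated step is a 1.8-fold lower number from compound 3 to compound 4 (0.26 log units; within the scatter). Compound 4 is expected at 210 umol/kg, within an estimated range of 110 umol/kg to 400 umol/kg.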

Compound 4, dose for half-maximal effect: 274 umol/kg
Compound 4: the middle estimate sits 1.3-fold (0.12 log units) below what was measured; the range from low to high includes it.
By their numbers in this assay, from the lowest: compounds 2, 1, 4 and 3 (each within the scatter of the next, the first and the last beyond it).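

In this assay, among these compounds, nitro in place of hydrogen on the aromatic carbon can now be read directly for the first time (a 1.4-fold lower number from compound 3 to compound 4 (0.14 log units; within the scatter)), and this step stays within the scatter. With nitro present, changing the group on the saturated ring carbon also stays within the scatter (a 1.7-fold higher number from compound 2 to compound 4 (0.23 log units; within the scatter); a 1.5-fold higher number from compound 1 to compound 4 (0.19 log units; within the scatter)), so neither change clearly shifts the dose needed here. No supporting evidence is available to explain these results.

Going by these compounds, it remains open whether an amine or a carboxylic acid on the same aromatic carbon would shift the number beyond the scatter.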